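Aryl urea series: from compound 2 to compound 3

The source may hold more compounds than are shown below. What is called first, only, known or untested is meant among the compounds shown, and "the series" means these compounds.

Measured so far:
compound 1 `O=C(Nc1ccc(I)cc1)Nn1c(-c2ccccc2)nc2ccccc2c1=O`, 60%
compound 2 `Cc1cccc(NC(=O)Nn2c(-c3ccccc3)nc3ccccc3c2=O)c1`, 59%

Within the data shown here, in a functional assay on the whole organism (strain albino) with Mus musculus as the target, at a dose of 100 mg/kg by the intraperitoneal route (a higher number here means more inhibition at the dose given (going by the name of the read-out), a lower number less inhibition), compound 2 stands level with compound 1: the only measured step, a number 1 percentage points lower from compound 1 to compound 2 (within the scatter), does not leave the scatter, so the two numbers cannot be ordered.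

Compound 3 `O=C(Nc1ccc(Br)cc1)Nn1c(-c2ccccc2)nc2ccccc2c1=O` differs from compound 2 in one place: 4-bromophenyl in place of 3-methylphenyl on an amide-type nitrogen. Among the measured compounds shown here, the one step that bears on this change is a number 1 percentage points lower from compound 1 to compound 2 (within the scatter), where exchanging 4-iodophenyl for 3-methylphenyl at the same amide-type nitrogen left the read-out in this assay unmoved. For the measured compounds named here, compound 3 now carries 4-bromophenyl at that nitrogen, and nothing among the measured compounds points to a shift beyond the scatter in either direction. The step of a number 1 percentage points higher from compound 2 to compound 3 (within the scatter) is therefore expected to stay within the scatter. Compound 3 is estimated at 60% in this assay, with a range from 45% to 75%.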

Compound 3, a percentage reported as inhibition, in the whole organism at one dose (the size of the read-out at that dose, not a potency): 58%
Beside the measured number, compound 3's estimate is 2 percentage points above it; measured number inside the range.
By their numbers in this assay, from the lowest: compounds 3, 2 and 1 (each within the scatter of the next).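

In this assay, among these compounds, the step of a number 2 percentage points lower from compound 1 to compound 3 (within the scatter) is the first exchange of one halogen for another on an aromatic carbon, bromo in place of iodo, and it stays inside the scatter. The step of a number 1 percentage points lower from compound 2 to compound 3 (within the scatter) adds a third aryl group on the same amide-type nitrogen, so 4-iodophenyl, 3-methylphenyl and 4-bromophenyl cannot be told apart at this place, whether the ring carries a halogen or a methyl. Nothing available accounts for this flat read-out.

On these data alone, whether it holds for a ring carrying an amine or a carboxylic acid remains open. So does the effect of replacing the aryl group on this nitrogen with a longer alkyl chain such as n-butyl, or of changing the phenyl group on the shared core.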